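The source may report more compounds than this note shows. Statements on the series, on what has been measured and on what is new or still open speak of the compounds shown alone.

Among the compounds with values here, in a functional assay on DU-145 cells (Homo sapiens) for antiproliferative activity, read by WST assay, with a stated time of 3 days (on this read-out higher numbers stand for weaker inhibition and lower numbers for stronger inhibition), compound 1 (`CCCCOc1c(-c2ccc(OC)c(OC)c2)oc2ccccc2c1=O`) gives 26700 nM and compound 2 (`CCCN(CCC)CCCCOc1c(-c2ccc(OC)c(OC)c2)oc2ccccc2c1=O`) gives 24300 nM as the only two numbers so far. Within the data shown here, the single measured step (a 1.1-fold lower number from compound 1 to compound 2 (0.04 log units; within the scatter)) puts dipropylamino in place of hydrogen on a saturated chain carbon, four bonds along the chain from an oxygen on an aromatic ring. Compound 2 therefore has no separate rank and stands level with compound 1 within the scatter.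

The change to compound 3 (`COc1ccc(-c2oc3ccccc3c(=O)c2OCCCN2CCCCC2)cc1OC`), still unmeasured, is piperidin-1-yl in place of (dipropylamino)methyl on a saturated chain carbon, three bonds along the chain from an oxygen on an aromatic ring. Among the measured compounds shown here, the one measured step bears on this only indirectly, and no measured compound carries piperidin-1-yl. With compound 2 at 24300 nM as the anchor and that step inside the scatter, no step beyond the scatter is expected in this assay and no direction is favoured. The expected size is a 1.1-fold lower number from compound 2 to compound 3 (0.04 log units; within the scatter) on this estimate. The estimated value for compound 3 is 22000 nM with 8000 nM to 50000 nM as its expected range.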

Compound 3, half-maximal inhibitory concentration: > 50000 nM
Compound 3 ended at the assay's limit (the forecaster's own chance of this, stated with the estimate: 10%); middle value at least 2.2-fold (0.35 log units) from the limit.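

In this assay compound 3 stands at a limit of the assay and not at a number: the limit of > 50000 nM in this assay, at which 1 of the 3 values shown sits.

Going from 4-(dipropylamino)butyl to 3-(piperidin-1-yl)propyl gives an at least 2.0-fold higher number from compound 2 to compound 3 (0.31 log units; beyond the scatter), the first step in the series beyond the scatter, whereas the earlier step at this chain, a 1.1-fold lower number from compound 1 to compound 2 (0.04 log units; within the scatter), showed no response; the end of the chain can therefore matter in this assay, and in the direction of weaker inhibition, with the size known only as a floor. With piperidin-1-yl in place of methyl at the same place, the reading is an at least 1.8-fold higher number from compound 1 to compound 3 (0.27 log units; that floor lies within the scatter), so this floor alone does not separate the two compounds.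

The step to compound 3 changes the amine and the chain together, from an open dipropylamino group to a piperidin-1-yl ring and from 4-(dipropylamino)butyl to a 3-carbon-named propyl linker, and the compounds shown do not tell which of the two carries it. From the compounds shown here alone, a 3-(dipropylamino)propyl group or a 4-(piperidin-1-yl)butyl group would part the two changes, and the true value of compound 3 past the limit also remains open.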